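The source may report more compounds than this note shows. Statements on the series, on what has been measured and on what is new or still open speak of the compounds shown alone.

Measured so far:
compound 1 `CC(C)(CC(=O)N[C@@H]1CCc2ccccc2N(Cc2ccc(-c3ccccc3-c3nn[nH]n3)cc2)C1=O)NCCO` — 30 nM
compound 2 `C[C@@H](O)CCNC(C)(C)CC(=O)N[C@@H]1CCc2ccccc2N(Cc2ccc(-c3ccccc3-c3nn[nH]n3)cc2)C1=O` — 10 nM

In a functional assay (Pituitary gland cell) with Rattus norvegicus as the target (a higher number here means that more compound is needed for the effect, a lower number that less compound is needed), compound 2 gives 10 nM, the lowest of the two numbers; compound 1 sits a 3.0-fold lower number from compound 1 to compound 2 (0.48 log units; beyond the scatter) away. Compound 3 `C[C@@H](O)CNC(C)(C)C(=O)N[C@@H]1CCc2ccccc2N(Cc2ccc(-c3ccccc3-c3nn[nH]n3)cc2)C1=O` carries 1-((2-hydroxypropyl)amino)-1-methylethyl in place of 2-((3-hydroxybutyl)amino)-2-methylpropyl on a carbonyl carbon. Going by the values given here, the one measured step, from compound 1 to compound 2, altered only the hydroxyalkyl end and moved the number by a 3.0-fold lower number from compound 1 to compound 2 (0.48 log units; beyond the scatter); the present change also shortens the link to the carbonyl, for which no step is available. The estimate for compound 3 is therefore uncertain, with a modest step of a 3.0-fold higher number from compound 2 to compound 3 (0.48 log units; beyond the scatter) expected. Compound 3 is estimated at 30 nM, range 8 nM to 120 nM.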

Compound 3, concentration for half-maximal effect: 300 nM
Compound 3: the middle estimate sits 10-fold (1.00 log units) below what was measured; measured number above the stated range.
By their numbers in this assay, from the lowest: compound 2; then compound 1; then compound 3.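

In this assay, 1-((2-hydroxypropyl)amino)-1-methylethyl on the carbonyl carbon gives a 30-fold higher number from compound 2 to compound 3 (1.48 log units; beyond the scatter) against 2-((3-hydroxybutyl)amino)-2-methylpropyl, and a 10-fold higher number from compound 1 to compound 3 (1.00 log units; beyond the scatter) against 2-((2-hydroxyethyl)amino)-2-methylpropyl. A change at the hydroxyalkyl end alone gave only a 3.0-fold lower number from compound 1 to compound 2 (0.48 log units; beyond the scatter), so this position tolerates the combined change of link and hydroxyalkyl end far less well. Nothing available accounts for the loss. On these data alone, the separate shares of the shorter link and the hydroxyalkyl end remain open. A 1-((3-hydroxybutyl)amino)-1-methylethyl group on the same carbonyl carbon would separate them.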